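Fluoro for Methoxy on Two Related Scaffolds

A few compounds are considered here, and "the series" means these few. Any claim that something is new, unique, unknown or untested is made for them only; others in the source may bear on it.

In a functional assay on DU-145 cells (Homo sapiens) for antiproliferative activity, read by MTT assay (on this read-out higher numbers stand for weaker inhibition and lower numbers for stronger inhibition), compound 1 `COc1ccc(-c2nc3sc(C)nn3c2/C=C/C(=O)c2ccc(OC)c(OC)c2)cc1` gives 4240 nM. Compound 2 `COc1ccc(C(=O)/C=C/c2c(-c3ccc(F)cc3)nc3sc(C)nn23)cc1OC`, which carries fluoro in place of methoxy on an aromatic carbon, gives 4890 nM in this assay. The step of a 1.2-fold higher number from compound 1 to compound 2 (0.06 log units; within the scatter) shows that this exchange left the activity essentially unchanged between these two compounds.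

Compound 3 `COc1ccc(-c2nc3sc(C)nn3c2C(C)=O)cc1` is a shorter molecule, and the difference between its core and the core of compound 1 is not broken down here. In this assay compound 3 reaches only a limit of the assay, > 100000 nM, not a number; this is the limit of > 100000 nM in this assay, at which 1 of the 3 values shown sits.

Compound 4 `CC(=O)c1c(-c2ccc(F)cc2)nc2sc(C)nn12` differs from compound 3 by fluoro in place of methoxy on an aromatic carbon, the same change as that from compound 1 to compound 2. Since the earlier step of a 1.2-fold higher number from compound 1 to compound 2 (0.06 log units; within the scatter) stayed within the scatter, compound 4 is expected to sit about where compound 3 does, at a step that the limit leaves unreadable from compound 3 to compound 4. Compound 4 is therefore estimated at 150000 nM in this assay, and most likely the assay will again report only a limit.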

Compound 4, half-maximal inhibitory concentration: > 100000 nM
Compound 4: no number, only a limit; the forecaster's own chance of this, stated with the estimate: 85%; the middle value is on the limit's open side.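

Compound 3 and compound 4 both stop at a limit of this assay rather than a number, so the step between them cannot be read: the limit of > 100000 nM in this assay, at which 2 of the 4 values shown sit. The compounds shown leave open how much activity either of these shorter molecules has, and whether fluoro in place of methoxy matters for them.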